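Thiourea series: cyclohexyl in place of dimethylaminophenyl

The source may report more compounds than this note shows. Statements on the series, on what has been measured and on what is new or still open speak of the compounds shown alone.

Measured so far in an assay on cells for inhibition of Pendrin (Mus musculus), read by fluorescence, with a stated time of 10 min; on this read-out higher numbers stand for weaker inhibition and lower numbers for stronger inhibition:
compound 1 `Cn1nc(COc2cc(F)cc(F)c2)c2c1CCN(C(=O)Nc1ccc(Cl)cc1)C2` gives 3100 nM
compound 2 `Cn1nc(COc2cc(F)cc(F)c2)c2c1CCN(C(=O)NC1CCCCC1)C2` gives > 10000 nM, a limit of the assay
compound 3 `CN(C)c1ccc(NC(=S)N2CCc3c(c(COc4cc(F)cc(F)c4)nn3C)C2)cc1` gives > 10000 nM, a limit of the assay

Compound 3 stands at the assay limit rather than at a number; compound 2 sits at the same limit, and only compound 1 returns a number. The compound to be measured next is compound 4 `Cn1nc(COc2cc(F)cc(F)c2)c2c1CCN(C(=S)NC1CCCCC1)C2`, which differs from compound 3 in one place: cyclohexyl in place of 4-(dimethylamino)phenyl on an amide-type nitrogen. One measured step is of the same kind, an aryl group replaced by cyclohexyl on an amide-type nitrogen: an at least 3.2-fold higher number from compound 1 to compound 2 (0.50 log units; beyond the scatter), a weakening that runs from a number into the limit. That step bears directly on the change at hand, with the difference that compound 1 starts from a number while compound 3 already starts from the limit. Given (the limit of > 10000 nM in this assay, at which 2 of the 3 values shown sit), the expectation in this assay is that compound 4 again returns a limit and no number, the most likely step being a further weakening, a step that the limit leaves unreadable from compound 3 to compound 4. Compound 4 is expected at 20000 nM, in the range 6000 nM to 60000 nM.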

Compound 4, half-maximal inhibitory concentration: > 10000 nM
Compound 4: only a limit was reported; the forecaster's own chance of this, stated with the estimate: 85%; the middle value does not contradict the limit.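

In this assay compound 4 gives > 10000 nM, which is a limit of the assay and not a number. Cyclohexyl on the thiocarbonyl side therefore does not lift the series off the limit, and the steps from compound 2 and from compound 3 cannot be read, since both ends of each are limits. The only readable step is an at least 3.2-fold higher number from compound 1 to compound 4 (0.50 log units; beyond the scatter), but that pair differs in more than one place, so it cannot be assigned to either the aryl-to-cyclohexyl change or the carbonyl-to-thiocarbonyl change, and the thiocarbonyl series still has no number anywhere: the limit of > 10000 nM in this assay, at which 3 of the 4 values shown sit.

With a single numbered compound, the 4-chlorophenyl carbonyl compound 1, the ranking of compound 2, compound 3 and compound 4 stays hidden, as does any separate effect of the thiocarbonyl. Still open, as far as these compounds go, is what 4-chlorophenyl would return on the thiocarbonyl, and what a benzyl group, a 4-methoxyphenyl group or a longer chain such as n-butyl would return on this amide-type nitrogen.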